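This account rests on a few compounds, and the source may have more. Where it says the series, first, only, none or still open, it means among the compounds named here.

Three compounds share one core and differ only in the amide. Compound 1 `CN(Cc1ccccc1)C(=O)c1ccc(-c2cc(C3=CC(=O)C=CC3=O)no2)s1` gives 11000 nM in a functional assay on PC-3 cells (Homo sapiens) for cytotoxicity, read by XTT assay, with a stated time of 72 h; a lower number here means a stronger inhibitor, a higher number a weaker inhibitor. Compound 2 `CCN(CC)C(=O)c1ccc(-c2cc(C3=CC(=O)C=CC3=O)no2)s1` gives 8900 nM in this assay, and a 1.2-fold lower number from compound 1 to compound 2 (0.09 log units; within the scatter). Compound 3 `CN(Cc1ccc(F)cc1)C(=O)c1ccc(-c2cc(C3=CC(=O)C=CC3=O)no2)s1` reaches only a limit in this assay, > 30000 nM, so for compound 3 no number is known, only that limit (the limit of > 30000 nM in this assay, at which 1 of the 3 values shown sits). The steps towards compound 3 were an at least 2.7-fold higher number from compound 1 to compound 3 (0.43 log units; beyond the scatter) and an at least 3.3-fold higher number from compound 2 to compound 3 (0.52 log units; beyond the scatter).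

Compound 4 `O=C1C=CC(=O)C(c2cc(-c3ccc(C(=O)NCC4CC4)s3)on2)=C1` carries (cyclopropylmethyl)amino in place of (4-fluorobenzyl)(methyl)amino on a carbonyl carbon. Among the compounds with values here, two measured steps bear on this change: an at least 2.7-fold higher number from compound 1 to compound 3 (0.43 log units; beyond the scatter) and an at least 3.3-fold higher number from compound 2 to compound 3 (0.52 log units; beyond the scatter). Both show the fluorobenzyl-bearing amide of compound 3 at the weak end, while the smaller dialkyl amide of compound 2 sits at the lower number. Taking the fluorobenzyl group away and returning to a small alkylamine is therefore expected to move the number back down, an at least 2.5-fold lower number from compound 3 to compound 4 (0.39 log units; beyond the scatter), towards the level of compound 2 rather than further up. Compound 4 is accordingly estimated at 12000 nM, with a range from 5000 nM to 30000 nM.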

Compound 4, half-maximal inhibitory concentration: > 30000 nM
Compound 4: no number, only a limit; the forecaster's own chance of this, stated with the estimate: 25%; middle value at least 2.5-fold (0.39 log units) away from the limit.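

Swapping out the (4-fluorobenzyl)(methyl)amino group did not bring the number back down in this assay: compound 4, with its (cyclopropylmethyl)amino group, stands at a limit and not at a number, as does compound 3, so the step between them cannot be read. Against the two amides with real numbers the change can be read, an at least 3.3-fold higher number from compound 2 to compound 4 (0.52 log units; beyond the scatter) and an at least 2.7-fold higher number from compound 1 to compound 4 (0.43 log units; beyond the scatter), so losing the six-membered aromatic ring does not by itself hold the number at the level of compound 2. The weak end of this short series now holds two different amides: the limit of > 30000 nM in this assay, at which 2 of the 4 values shown sit.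

On these data alone, it stays open whether the amide hydrogen or the cyclopropylmethyl group goes with this step, and a secondary ethylamino amide or a dimethylamino amide could separate the two. As far as these compounds go, how far compound 3 and compound 4 lie beyond their limit also stays open.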